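Shortening the azide-bearing chain on compound 2

This account rests on a few compounds, and the source may have more. Where it says the series, first, only, none or still open, it means among the compounds named here.

Measured so far in a functional assay on CHO cells for antagonist activity at Gonadotropin-releasing hormone receptor (Homo sapiens), read by a luciferase reporter, with a stated time of 30 min; a higher number here means a weaker inhibitor, a lower number a stronger inhibitor:
compound 1 `CCNC(=O)Nc1ccc(-c2nc3n(Cc4c(F)cccc4F)cc(C(=O)OCC)c(=O)n3c2CN(CC(=O)NCc2cn(CCOCCOCCOCCOCCN=[N+]=[N-])nn2)Cc2ccccc2)cc1` — 832 nM
compound 2 `CCNC(=O)Nc1ccc(-c2nc3n(Cc4c(F)cccc4F)cc(C(=O)NCc4cn(CCOCCOCCOCCN=[N+]=[N-])nn4)c(=O)n3c2CN(C)Cc2ccccc2)cc1` — < 10000 nM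
compound 3 `CCNC(=O)Nc1ccc(-c2nc3n(Cc4c(F)cccc4F)cc(C(=O)OCC)c(=O)n3c2CN(C)Cc2ccccc2)cc1` — 70.8 nM

Among the measured compounds shown here, compound 3 gives 70.8 nM in this assay, and compound 1 gives 832 nM; no single-point step joins these two, so only the two numbers themselves are on record. For compound 2 this assay gives only a limit, < 10000 nM, which is the limit of < 10000 nM in this assay, at which 1 of the 3 values shown sits. On the numbers shown, compound 2 therefore stands apart from compound 1 and compound 3 in that it has no value of its own, only a bound; nothing more can be said of where it sits relative to them.

Compound 4 `CCNC(=O)Nc1ccc(-c2nc3n(Cc4c(F)cccc4F)cc(C(=O)NCc4cn(CCOCCOCCN=[N+]=[N-])nn4)c(=O)n3c2CN(C)Cc2ccccc2)cc1` is the unmeasured neighbour of compound 2. The difference between the two is azido in place of 2-azidoethoxy on a saturated chain carbon, two bonds along the chain from an oxygen on a saturated carbon. For the measured compounds named here, no measured step of this kind exists among the three compounds, so there is no precedent for the size of the change. The expectation is that the step that the limit leaves unreadable from compound 2 to compound 4 stays within the usual scatter, with no clear direction. On that basis compound 4 is estimated at 3000 nM in this assay, with a range from 500 nM to 10000 nM.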

Compound 4, half-maximal inhibitory concentration: < 10000 nM
Compound 4 gave a limit, no number; the forecaster's own chance of this, stated with the estimate: 40%; the middle value lies beyond the limit too.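

Compound 2 and compound 4 each have only a limit, not a number, in this assay, so no step between them can be read: the limit of < 10000 nM in this assay, at which 2 of the 4 values shown sit.

Still open, on these data alone, is whether azido in place of 2-azidoethoxy on this chain changes inhibition in either direction, and how far the true potency of either compound lies from that limit.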